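The source may report more compounds than this note shows. Statements on the series, on what has been measured and on what is new or still open speak of the compounds shown alone.

Compound 1 `C[C@@H](NC(=O)c1ccc(C#Cc2ccccc2)cn1)C(C)(C)O` reaches 43.2% in an ADME assay on HEK293 cells for agonist activity at metabotropic glutamate receptor 5 (Rattus norvegicus), read by fluorescence and calcium flux; a lower number here means a smaller maximal response, a higher number a larger maximal response. Compound 2 `C[C@@H](NC(=O)c1ccc(C#Cc2cc(F)cc(F)c2)cn1)C(C)(C)O` reaches 37.9% in this assay, and the change of a number 5.3 percentage points lower from compound 1 to compound 2 (within the scatter) is within the scatter. Of the two numbers shown, that of compound 2 is the lower, but compound 1 lies within the scatter of it, so no real order between the two can be read. Compound 3 `Cc1cccc(C#Cc2ccc(C(=O)N[C@H](C)C(C)(C)O)nc2)c1` has not yet been measured in this assay. It differs from compound 2 in one place: 3-methylphenyl in place of 3,5-difluorophenyl on a triple-bonded carbon. Within the data shown here, only the step from compound 1 to compound 2 bears on this change, since it altered the same group on the triple-bonded carbon, and that step stayed within the scatter. A step of a number 2.1 percentage points higher from compound 2 to compound 3 (within the scatter) is therefore expected, nothing beyond the scatter. For compound 3 an efficacy of 40% is estimated, with a range from 26% to 54%.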

Compound 3, largest response reached (reported as efficacy), in percent of the reference or control that the assay uses: 20.8%
Beside the measured number, compound 3's estimate is 19.2 percentage points above it, outside the stated range (below it).
By their numbers in this assay, from the lowest: compound 3; then compounds 2 and 1 (each within the scatter of the next).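

In this assay, the ring on the triple-bonded carbon proves sensitive to the group it carries: 3-methylphenyl in place of 3,5-difluorophenyl gives a number 17.1 percentage points lower from compound 2 to compound 3 (beyond the scatter), and methyl in place of hydrogen on an aromatic carbon gives a number 22.4 percentage points lower from compound 1 to compound 3 (beyond the scatter). The earlier fluorine change alone, a number 5.3 percentage points lower from compound 1 to compound 2 (within the scatter), had shown no such shift, so this position can move the maximal response, and a single methyl is enough to do so. No measurement at hand accounts for the drop.

The compounds shown leave open whether an ethyl group, a methoxy group or a chlorine in place of the methyl would give a similar response. They also leave open whether a ring carrying both methyl and fluorine would follow compound 3 or compound 2.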